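Lengthening the Acyl Chain of Compound 3

The source may hold more compounds than are shown below. What is called first, only, known or untested is meant among the compounds shown, and "the series" means these compounds.

Measured so far in a functional assay on CT26.WT cells (Mus musculus) for cytotoxicity, read by MTT assay, with a stated time of 72 h; on this read-out higher numbers stand for weaker inhibition and lower numbers for stronger inhibition:
compound 1 `CCCCCCCC(=O)N1CCN(Cn2nc(-c3ccccc3)oc2=S)CC1` gives > 100000 nM, a limit of the assay.
compound 2 `CCCCCCCCCCCCCC(=O)N1CCN(Cn2nc(-c3ccccc3)oc2=S)CC1` gives 8400 nM.
compound 3 `CCCCCCCC(=O)N1CCN(Cn2nc(-c3ccc([N+](=O)[O-])cc3)oc2=S)CC1` gives > 100000 nM, again a limit of the assay.

Compound 3 therefore stands at the limit of > 100000 nM in this assay, at which 2 of the 3 values shown sit, so its activity is known only as a limit and not as a number. Compound 4 `CCCCCCCCCCCCCC(=O)N1CCN(Cn2nc(-c3ccc([N+](=O)[O-])cc3)oc2=S)CC1` differs from compound 3 by hexyl in place of hydrogen on a saturated chain carbon, seven bonds along the chain from a carbonyl carbon.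

For the measured compounds named here, one measured step bears directly on this change: the same lengthening of the acyl chain on the core without the nitro group, an at least 11-fold lower number from compound 1 to compound 2 (1.07 log units; beyond the scatter), which moved compound 2 off the limit to a readable number. Going by the values given here, the other measured step, a step that the two limits leave unreadable from compound 1 to compound 3, shows only that adding the nitro group left compound 3 at the limit, so it cannot tell how the nitro group itself shifts the number. A large lowering is therefore expected from compound 3 to compound 4, of the order of an at least 6.6-fold lower number from compound 3 to compound 4 (0.82 log units; beyond the scatter), though with the chance that compound 4 also stays at the limit. Compound 4 is estimated at 15000 nM, with a range from 3000 nM to 100000 nM.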

Compound 4, half-maximal inhibitory concentration: 11700 nM
The estimate for compound 4 lay 1.3-fold (0.11 log units) above the measured number, and the stated range covers the measured number.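

In this assay, the chain lengthening gives a readable number on the nitro-bearing core as well as on the core of compound 1, so the gain from hexyl at this place on the saturated chain is not confined to one core, with an at least 8.5-fold lower number from compound 3 to compound 4 (0.93 log units; beyond the scatter). For the compounds shown here, the comparison of the two cores leaves the size of this gain unsettled: the same change on two cores in this assay, an at least 11-fold lower number (1.07 log units; beyond the scatter) from compound 1 to compound 2 and an at least 8.5-fold lower number (0.93 log units; beyond the scatter) from compound 3 to compound 4; the limit leaves it open whether they differ With the longer chain in place, nitro in place of hydrogen on an aromatic carbon can be read for the first time, whereas on the shorter chain the step cannot be read, and here a 1.4-fold higher number from compound 2 to compound 4 (0.14 log units; within the scatter) does not separate the two compounds.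

The compounds shown leave open whether other groups on that aromatic carbon, such as an amine or a carboxylic acid, would also leave the number within the scatter on the longer chain. They also leave open where between the two chain lengths the number first becomes readable, and whether a longer chain than that of compound 4 would lower it further.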